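The compounds below may be only part of what the source reports. "The series", "measured", "known", "first", "only" and "open" are said of these compounds alone.

Working notes on the series

The shared core carries an aminotriazine bearing a hydroxymethylphenyl group, varied only at the substituted amine. Compound 1 `Nc1nc(NCc2ccccc2F)nc(-c2ccccc2CO)n1` gives 4.27 in a functional assay on cells for positive allosteric modulation of G-protein coupled receptor 68 (Homo sapiens), read by a luciferase reporter and cAMP accumulation, with a stated time of 30 min, at pH 6.8 and pH 8.3, in the presence of a further agent that is not named here; on this read-out higher numbers stand for higher potency (the scale is a negative logarithm) and lower numbers for lower potency. Compound 2 `Nc1nc(NCc2cccc(F)c2)nc(-c2ccccc2CO)n1` gives 4.52 in this assay, and compound 3 `Nc1nc(NCc2cccc(Cl)c2)nc(-c2ccccc2CO)n1` gives 4.97 in this assay. Compound 3 holds the highest number of the three: the gap to compound 2 and the gap to compound 1 both lie beyond the scatter, with the step of a number 0.45 log units higher from compound 2 to compound 3 (beyond the scatter) and the step of a number 0.70 log units higher from compound 1 to compound 3 (beyond the scatter), while the step of a number 0.25 log units higher from compound 1 to compound 2 (within the scatter) stays within it.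

Compound 4 `Nc1nc(Nc2ccccc2)nc(-c2ccccc2CO)n1` is the next structure. Relative to compound 3 the change is phenyl in place of 3-chlorobenzyl on a nitrogen on an aromatic ring. Two things move at once: the chlorine is lost, and the saturated chain carbon between the aromatic nitrogen and the phenyl is gone. The measured steps speak only to the first part. The step of a number 0.45 log units higher from compound 2 to compound 3 (beyond the scatter) shows that chloro in place of fluoro raised the number modestly, so removing the chlorine altogether is expected to give some of that back. For the measured compounds named here, for the loss of the chain carbon no measured step exists in this set, and its effect is unknown here.

On that basis compound 4 is expected to fall below compound 3, with an estimated step of a number 0.57 log units lower from compound 3 to compound 4 (beyond the scatter) in this assay. The estimate for compound 4 is 4.4, with a range from 3.8 to 5.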

Compound 4, negative logarithm of the antagonist equilibrium constant: 3.92
Estimate against measurement, compound 4: 0.48 log units above, and the stated range covers the measured number.
By their numbers in this assay, from the lowest: compound 4; then compounds 1 and 2 (each within the scatter of the next); then compound 3.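

Working back from the benzyl groups, phenyl on this nitrogen gives the lowest number of the series in this assay, and each of the three steps down lies beyond the scatter: from the 3-chlorobenzyl compound (a number 1.05 log units lower from compound 3 to compound 4 (beyond the scatter)), from the 3-fluorobenzyl compound (a number 0.60 log units lower from compound 2 to compound 4 (beyond the scatter)) and from the 2-fluorobenzyl compound (a number 0.35 log units lower from compound 1 to compound 4 (beyond the scatter)). The earlier compounds changed only the halogen or its place on the benzyl group, whereas this change shows that all three halogenated benzyl groups hold higher numbers than phenyl, with no compound shown going against that order, and that the size of the loss depends on which benzyl group is replaced. Nothing available here gives a reason for this drop.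

Still open, going by these compounds, is how much of the loss belongs to the chain carbon and how much to the halogen, a question that an unsubstituted benzyl group or a 3-chlorophenyl group on this nitrogen would separate. Also open, on these data alone, is whether a longer chain, such as 2-phenylethyl, or a larger halogen such as bromo on the benzyl group would carry the number beyond that of compound 3.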